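This account rests on a few compounds, and the source may have more. Where it says the series, first, only, none or still open, it means among the compounds named here.

Three compounds have numbers in a functional assay on SEM cells (Homo sapiens) for inhibition, read by MTT assay, with a stated time of 72 h; on this read-out lower numbers stand for stronger inhibition and higher numbers for weaker inhibition. There, compound 1 (`COc1cc(NC(=O)/C=C/c2cccc(OCc3ccccc3)c2)cc(OC)c1OC`) gives 8500 nM, compound 2 (`C=C(Br)C(=O)Nc1cccc(/C=C/C(=O)Nc2ccc(OC)c(OC)c2)c1`) gives 3 nM and compound 3 (`C=C(Br)C(=O)Nc1cccc(/C=C/C(=O)Nc2cc(OC)cc(OC)c2)c1`) gives 40 nM. Compound 3 therefore holds the middle place among the three numbers, with compound 2 lower and compound 1 much higher, and both gaps lie beyond the scatter.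

The next compound, compound 4 (`C=C(Br)C(=O)Nc1cccc(/C=C/C(=O)Nc2cc(OC)c(OC)c(OC)c2)c1`), has not yet been measured in this assay. It differs from compound 3 by methoxy in place of hydrogen on an aromatic carbon, ortho to two methoxy groups and para to a large group. Among the measured compounds shown here, no measured pair shows this change on its own, so any expectation is indirect. Compound 4 would carry the methoxy placements of both other bromine-bearing compounds, so its number is expected to fall between those of compound 2 at 3 nM and compound 3 at 40 nM. A modest step toward a lower number is therefore expected in this assay, although it may not clear the scatter. The estimate means an expected step of a 2.7-fold lower number from compound 3 to compound 4 (0.43 log units; beyond the scatter). For compound 4, the estimated value is 15 nM, with an expected range from 3 nM to 70 nM.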

Compound 4, half-maximal inhibitory concentration: 18 nM
Compound 4: middle estimate off by 1.2-fold (0.08 log units), on the low side, and the stated range covers the measured number.
By their numbers in this assay, from the lowest: compound 2; then compound 4; then compound 3; then compound 1.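

In this assay, methoxy in place of hydrogen on the aromatic carbon ortho to two methoxy groups and para to a large group brings a 2.2-fold lower number from compound 3 to compound 4 (0.35 log units; beyond the scatter), so this position accepts a methoxy group and the number improves, whereas the same kind of change made elsewhere on that ring brings a 6.0-fold higher number from compound 2 to compound 4 (0.78 log units; beyond the scatter), showing that the direction of the step depends on where the methoxy group enters. Both of these steps are modest beside the large one seen when ((1-bromoethenyl)carbonyl)amino stands in place of benzyloxy, a 470-fold lower number from compound 1 to compound 4 (2.67 log units; beyond the scatter), so among these compounds the methoxy pattern tunes the number while that other exchange moves it much further. Nothing available here gives a measured reason for any of these steps.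

The compounds shown leave open whether a group other than methoxy at this position, such as ethoxy, a hydroxyl group or a fluorine atom, would lower the number further or raise it. They also leave open how much of the large step belongs to the bromine atom, which a chlorine atom or a plain hydrogen in its place would help to settle.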